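Swapping an Aryl Amide for a Dimethylaminoethyl Amide

This account rests on a few compounds, and the source may have more. Where it says the series, first, only, none or still open, it means among the compounds named here.

Compound 1, `O=C(CCC(=O)OCCCCCCSc1ccc([N+](=O)[O-])c2nonc12)Nc1ccccc1`: 2120 nM
Compound 2, `O=C(CCC(=O)OCCCCCCSc1ccc([N+](=O)[O-])c2nonc12)Nc1ccc(C(F)(F)F)cc1`: 3200 nM

Both compounds carry the same core and were tested in a functional assay on HOS cells (Homo sapiens) for inhibition, read by MTT assay, with a stated time of 72 h; on this read-out lower numbers stand for stronger inhibition and higher numbers for weaker inhibition. In this assay compound 1 gives 2120 nM, and compound 2 gives 3200 nM. Among the measured compounds shown here, the single step linking them, a 1.5-fold higher number from compound 1 to compound 2 (0.18 log units; within the scatter), is small. On the numbers shown, compound 2 stands with the highest of the two numbers, but its gap to compound 1 lies within the scatter, so no order between the two can be read from this.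

Compound 3, `CN(C)CCNC(=O)CCC(=O)OCCCCCCSc1ccc([N+](=O)[O-])c2nonc12`, is not yet measured. It differs from compound 2 in one place: 2-(dimethylamino)ethyl in place of 4-(trifluoromethyl)phenyl on an amide-type nitrogen. For the measured compounds named here, none of the measured steps bears on this change; the only one measured, a 1.5-fold higher number from compound 1 to compound 2 (0.18 log units; within the scatter), concerns a trifluoromethyl in place of hydrogen on an aromatic carbon and tells nothing about what a 2-(dimethylamino)ethyl in place of 4-(trifluoromethyl)phenyl on an amide-type nitrogen does. Going by the values given here, the data therefore give no direction for this step, and the estimate rests only on the shared core. Compound 3 is expected to give about 3000 nM, with a range from 900 nM to 10000 nM. The step this estimate means, a 1.1-fold lower number from compound 2 to compound 3 (0.03 log units; within the scatter), is expected to be none beyond the scatter.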

Compound 3, half-maximal inhibitory concentration: 5020 nM
The estimate for compound 3 lay 1.7-fold (0.22 log units) below the measured number; the measured number falls inside the stated range.
By their numbers in this assay, from the lowest: compounds 1, 2 and 3 (each within the scatter of the next, the first and the last beyond it).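

Placing 2-(dimethylamino)ethyl instead of 4-(trifluoromethyl)phenyl on the amide-type nitrogen gives a 1.6-fold higher number from compound 2 to compound 3 (0.20 log units; within the scatter) in this assay, so this swap of an aromatic group for an open chain leaves no separation between the two compounds that can be read. Set against the plain phenyl amide, the same chain gives a 2.4-fold higher number from compound 1 to compound 3 (0.37 log units; beyond the scatter), which is the only step in this short series to pass beyond the scatter, and it is a modest one. Across these three compounds, then, a six-membered aromatic ring on this nitrogen is not required for a number of the same general order, although the phenyl amide does keep a modest edge over the chain; nothing measured here accounts for that difference.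

The compounds shown leave open whether the amine of the new group or simply the loss of the aromatic ring lies behind the step from phenyl, a question that a plain ethyl group or a morpholine on the same nitrogen would help to settle. Also open, on these data alone, is how a carboxylic acid or a longer amine chain in that place would read in this assay.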